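Swapping the aryl group on a sulfonamide nitrogen

The source may report more compounds than this note shows. Statements on the series, on what has been measured and on what is new or still open speak of the compounds shown alone.

Compound 1 `O=C1NCCN1c1ccc(S(=O)(=O)Nc2ccc3[nH]ccc3c2)cc1` gives 87 nM in a functional assay on M21 cells (Homo sapiens) for antiproliferative activity, read by sulforhodamine B assay, with a stated time of 48 h; on this read-out lower numbers stand for stronger inhibition and higher numbers for weaker inhibition.
Compound 2 `Cc1ccc(NS(=O)(=O)c2ccc(N3CCNC3=O)cc2)cc1C` gives 94 nM in this assay.
Compound 3 `O=C1NCCN1c1ccc(S(=O)(=O)Nc2ccc3c(c2)CCC3)cc1` gives 130 nM in this assay.

Compound 2 has the second highest of these three numbers, but its distances to compound 1 and to compound 3 both lie within the scatter of repeated measurements, so the three compounds cannot be told apart on this read-out. Compound 4 `COc1cccc(NS(=O)(=O)c2ccc(N3CCNC3=O)cc2)c1` has not yet been measured. It differs from compound 2 in a single place: 3-methoxyphenyl in place of 3,4-dimethylphenyl on a sulfonamide nitrogen. Within the data shown here, no pair of measured compounds shows a change of this kind, so there is no measured step to lean on. In this assay a modest rise in the number is expected, a 1.6-fold higher number from compound 2 to compound 4 (0.20 log units; within the scatter), small enough that it could still fall within the scatter. Compound 4 is therefore estimated at 150 nM, with a range from 60 nM to 400 nM.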

Compound 4, half-maximal inhibitory concentration: 65 nM
For compound 4 the middle estimate is 2.3-fold (0.36 log units) above the measured one; measured number inside the range.
By their numbers in this assay, from the lowest: compounds 4, 1, 2 and 3 (each within the scatter of the next).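

In this assay, putting 3-methoxyphenyl in place of 3,4-dimethylphenyl on a sulfonamide nitrogen gives a 1.4-fold lower number from compound 2 to compound 4 (0.16 log units; within the scatter). This single step, the only one measured at this position, shows that an aryl group with one hydrogen-bond acceptor can replace one with none while the read-out stays within the scatter. Nothing measured here explains this result.

The compounds shown leave open how an aryl group carrying an amine or a carboxylic acid would read in this assay, and whether a plain phenyl group would read the same.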